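From carboxy to ethoxycarbonyl at the assay limit

The compounds below may be only part of what the source reports. "The series", "measured", "known", "first", "only" and "open" are said of these compounds alone.

Compounds measured in a functional assay on Z-138 cells (Homo sapiens) for inhibition, read by luminescence and CellTiter-Glo, with a stated time of 72 h; on this read-out lower numbers stand for stronger inhibition and higher numbers for weaker inhibition:
- Compound 1 `C=CC(=O)Nc1ccc(Cn2nc(-c3ccc(Oc4ccccc4)cc3)cc2C(=O)O)cc1`: > 60000 nM, a limit
- Compound 2 `C/C=C/C(=O)Nc1ccc(Cn2nc(-c3ccc(Oc4ccccc4)cc3)cc2C(=O)O)cc1`: > 60000 nM, a limit

Compound 1 has no exact number on this read-out. Its entry of > 60000 nM is a limit. The same holds across the small set: the limit of > 60000 nM in this assay, at which 2 of the 2 values shown sit.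

Compound 3 `C=CC(=O)Nc1ccc(Cn2nc(-c3ccc(Oc4ccccc4)cc3)cc2C(=O)OCC)cc1` keeps the core of compound 1 and changes in one place: ethyl in place of hydrogen on an oxygen next to a carbonyl group. The same difference can be read as carboxy to ethoxycarbonyl.

Among the measured compounds shown here, the only measured step is a step that the two limits leave unreadable from compound 1 to compound 2, and it concerns a different change, prop-1-en-1-yl in place of vinyl. It therefore offers no size to carry over to compound 3.

The expectation rests instead on compound 1, whose limit of > 60000 nM leaves room in one direction only. In this assay, a modest move towards stronger inhibition is expected, although compound 3 may well remain at a limit. The expected size is an at least 3.0-fold lower number from compound 1 to compound 3 (0.47 log units; beyond the scatter), and this is a loose estimate. Compound 3 is estimated at 20000 nM, with an expected range of 4000 nM to 60000 nM.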

Compound 3, half-maximal inhibitory concentration: 12500 nM
For compound 3 the middle estimate is 1.6-fold (0.20 log units) above the measured one, and the stated range covers the measured number.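

Compound 3 holds the only exact number among the compounds shown in this assay, and it makes this position the one place where a change can be sized. Up to this point the read-out had offered limits only: the limit of > 60000 nM in this assay, at which 2 of the 3 values shown sit. Ethyl in place of hydrogen on an oxygen next to a carbonyl group, the change from carboxy to ethoxycarbonyl, gives an at least 4.8-fold lower number from compound 1 to compound 3 (0.68 log units; beyond the scatter), and this size is a minimum, since one end of the step is a limit.

What the compounds shown leave open is whether this step belongs to ethyl itself or would also appear with a shorter or longer chain on the same oxygen, such as methoxycarbonyl or propoxycarbonyl, or with a primary amide in its place. On these data alone, the step from vinyl to prop-1-en-1-yl cannot be read between its two limits, so what that change does on the ethoxycarbonyl compound, where an exact number would be within reach, also remains unknown.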